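Benzylamino to phenyl on the methylpiperidine carbonyl

A few compounds are considered here, and "the series" means these few. Any claim that something is new, unique, unknown or untested is made for them only; others in the source may bear on it.

Compound 2 `CN1CCC(C(=O)N2Cc3c(NC(=O)NCc4ccccc4)n[nH]c3C2(C)C)CC1` carries a benzylamino group on the carbonyl carbon next to the shared core, and compound 4 `CN1CCC(C(=O)N2Cc3c(NC(=O)c4ccccc4)n[nH]c3C2(C)C)CC1` is its benzoyl counterpart. In a physicochemical assay for solubility, at pH 7 (a higher number here means a more soluble compound, a lower number a less soluble compound), compound 2 gives only a limit of the assay, > 225000 nM, so its true number is not known. The two pivaloyl analogues give numbers: compound 1 `CC(C)(C)C(=O)N1Cc2c(NC(=O)c3cccnc3)n[nH]c2C1(C)C` gives 207000 nM in this assay, and compound 3 `CC(C)(C)C(=O)N1Cc2c(NC(=O)c3ccncc3)n[nH]c2C1(C)C` gives 205000 nM; the step of a 1.0-fold lower number from compound 1 to compound 3 (0.00 log units; within the scatter) is within the scatter. Compound 4 differs from compound 2 as follows: phenyl in place of benzylamino on a carbonyl carbon. Among the measured compounds shown here, no measured step concerns this change; the single measured step exchanges one pyridyl for another on a different carbonyl and says nothing about benzylcarbamoyl against benzoyl. The limit of > 225000 nM in this assay, at which 1 of the 3 values shown sits, shows that compound 2 already sits at the upper end of what this assay can report, while compounds 1 and 3 sit just beneath it. The expected step is therefore an at least 1.1-fold lower number from compound 2 to compound 4 (0.05 log units; that floor lies within the scatter), with no direction claimed beyond the scatter. Compound 4 is expected to give about 200000 nM in this assay, with a range from 100000 nM to 230000 nM, and a fair chance that only a limit is reported again.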

Compound 4, solubility: > 225000 nM
Compound 4: a limit, no number; the forecaster's own chance of this, stated with the estimate: 40%; at least 1.1-fold (0.05 log units) between middle value and limit.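

In this assay compound 4 gives > 225000 nM, a limit of the assay. Compound 2 gives > 225000 nM, also a limit, and no step from compound 2 to compound 4 can be read: the limit of > 225000 nM in this assay, at which 2 of the 4 values shown sit.

The compounds shown leave open the true numbers of both compounds, and so the size and direction of any change from benzylcarbamoyl to benzoyl in this assay.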